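The compounds below may be only part of what the source reports. "The series", "measured", "known", "first", "only" and "open" are said of these compounds alone.

Of the compounds shown here, two have been measured so far. Compound 1 `c1ccc2c(c1)CN[C@@H](CN(CCCCNC1CCOCC1)[C@H]1CCCc3cccnc31)C2` in a functional assay on cells for antagonist activity at C-X-C chemokine receptor type 4 (Homo sapiens), read by fluorescence and calcium flux, with stated times of 25 min and 90 s (a lower number here means a stronger inhibitor, a higher number a weaker inhibitor), gives 29.4 nM. Compound 2 `c1ccc2c(c1)CN[C@@H](CN(CCCCNC1CCSCC1)[C@H]1CCCc3cccnc31)C2` gives 54.7 nM in this assay. The single step between them, a 1.9-fold higher number from compound 1 to compound 2 (0.27 log units; within the scatter), comes from thian-4-yl in place of oxan-4-yl on an amine nitrogen; on the numbers shown, compound 2 and compound 1 sit side by side, within the usual scatter of one another.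

Compound 3 `CC(C)(CN)CCN(C[C@H]1Cc2ccccc2CN1)[C@H]1CCCc2cccnc21` has not yet been measured. It differs from compound 2 by a group of 5 heavy atoms (4 carbon, 1 nitrogen; no ring) in place of a group of 9 heavy atoms (7 carbon, 1 nitrogen, 1 sulfur; one six-membered non-aromatic ring with 1 hetero atom), on a saturated chain carbon, two bonds along the chain from an amine nitrogen. Within the data shown here, the one measured step concerns only the exchange of one six-membered ring for another and says nothing about removing the ring together with part of the chain, so no measured step bears directly on this change. The step from compound 2 is expected to be a 1.1-fold higher number from compound 2 to compound 3 (0.04 log units; within the scatter), with a wide range. Compound 3 is estimated at 60 nM, between 15 nM and 250 nM.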

Compound 3, half-maximal inhibitory concentration: 69 nM
Beside the measured number, compound 3's estimate is 1.2-fold (0.06 log units) below it; the range from low to high includes it.
By their numbers in this assay, from the lowest: compounds 1, 2 and 3 (each within the scatter of the next, the first and the last beyond it).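

On a saturated chain carbon, two bonds along the chain from an amine nitrogen, a group with no ring, 1-(aminomethyl)-1-methylethyl, stays within the scatter of the ring-bearing group of compound 2: a 1.3-fold higher number from compound 2 to compound 3 (0.10 log units; within the scatter) in this assay shows that this six-membered ring can go without a step that can be told from the scatter. Set against the oxan-4-yl compound, the change is larger, with a 2.3-fold higher number from compound 1 to compound 3 (0.37 log units; beyond the scatter) in this assay as a modest step beyond the scatter. Nothing given here accounts for either step.

The compounds shown leave open which part of the new group matters. A straight aminopropyl group, or a carboxylic acid in place of the terminal amine, would help separate the branching from the amine.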